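This account rests on a few compounds, and the source may have more. Where it says the series, first, only, none or still open, it means among the compounds named here.

Measured so far:

Compound 1 `CN(C)c1nc(Br)nc2c1ncn2[C@@H]1C[C@@H](O)[C@H](CO)O1` gives a limit of > 300 uM.
Compound 2 `Nc1nc(Br)nc2c1ncn2[C@@H]1C[C@@H](O)[C@H](CO)O1` gives 41 uM.
Compound 3 `CSc1nc(N(C)C)c2ncn([C@@H]3C[C@@H](O)[C@H](CO)O3)c2n1` gives a limit of > 300 uM.

All three were tested in a functional assay on HL-60 cells (Homo sapiens); a lower number here means a stronger inhibitor, a higher number a weaker inhibitor. For compound 1 the reading in this assay is a limit only, > 300 uM, not a number. For compound 3 the reading is also a limit only, > 300 uM. Among the measured compounds shown here, compound 2 is the only one with a real number, 41 uM.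

Two single changes connect these compounds. The first is amino in place of dimethylamino on an aromatic carbon, and it produced an at least 7.3-fold lower number from compound 1 to compound 2 (0.86 log units; beyond the scatter). The second is methylsulfanyl in place of bromo on an aromatic carbon; here the step that the two limits leave unreadable from compound 1 to compound 3 cannot be read because two of the three values sit at the limit of > 300 uM in this assay, at which 2 of the 3 values shown sit.

The unmeasured compound 4 `CSc1nc(N)c2ncn([C@@H]3C[C@@H](O)[C@H](CO)O3)c2n1` is made from compound 3 by amino in place of dimethylamino on an aromatic carbon. For the measured compounds named here, this is the same kind of change as the one from compound 1 to compound 2, but not the same: in compound 4 the group sits meta to a methylsulfanyl group, whereas in compound 2 it sits meta to a bromo group. How the two cores differ is methylsulfanyl in place of bromo on an aromatic carbon.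

The change from compound 1 to compound 2 was at least modest, so a step of similar direction, an at least 3.0-fold lower number from compound 3 to compound 4 (0.47 log units; beyond the scatter), is expected for compound 4. Compound 4 is therefore estimated at 100 uM, with a likely range from 30 uM to 300 uM.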

Compound 4, concentration for 50% inhibition: > 300 uM
Compound 4: no number, only a limit; the forecaster's own chance of this, stated with the estimate: 40%; at least 3.0-fold (0.47 log units) between middle value and limit.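

In this assay compound 4 gives > 300 uM, which is a limit of the assay and not a number. The change of dimethylamino to amino, which on the bromo-bearing core gave an at least 7.3-fold lower number from compound 1 to compound 2 (0.86 log units; beyond the scatter), therefore shows no measurable carry-over to the methylsulfanyl-bearing core, but it is not shown to fail there either, since the steps that start or end at a limit on both sides cannot be read, and any real difference between compound 3 and compound 4 would lie out of sight: the limit of > 300 uM in this assay, at which 3 of the 4 values shown sit.

What can be read is the comparison with amino held fixed, methylsulfanyl in place of bromo, which gives an at least 7.3-fold higher number from compound 2 to compound 4 (0.86 log units; beyond the scatter), so in this pair the amino group alone does not secure a measurable number and the outcome also depends on the neighbouring group on the core.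

Open, from the compounds shown here alone, is whether other groups in place of bromo, such as chloro or methoxy, keep a measurable number alongside amino. Also open, going by these compounds, is how methylamino, standing in for amino on the core of compound 2, would fall between the readings of compound 1 and compound 2.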